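The source may report more compounds than this note shows. Statements on the series, on what has been measured and on what is new or still open speak of the compounds shown alone.

Within the data shown here, in a functional assay on L1210 cells (Mus musculus) for antiproliferative activity, read by cell counting, with a stated time of 2 days (on this read-out higher numbers stand for weaker inhibition and lower numbers for stronger inhibition), compound 1 (`COc1ccc(Nc2nc(N)c(C(=O)c3ccccc3)s2)cc1`) gives 850 nM, the only actual number so far. Compound 2 (`Nc1nc(Nc2ccc(Cl)cc2)sc1C(=O)c1ccccc1`) gives > 10000 nM, which is a limit of the assay. Among the measured compounds shown here, the one measured step, chloro in place of methoxy on an aromatic carbon, is large: an at least 11-fold higher number from compound 1 to compound 2 (1.07 log units; beyond the scatter). Compound 3 (`COc1ccc(Nc2nc(N)c(C(=O)c3cccc(OC)c3)s2)cc1`) keeps the methoxy that this step replaced and differs elsewhere: methoxy in place of hydrogen on an aromatic carbon, meta to a large group. For the measured compounds named here, the measured step bears on this only indirectly, showing that one substituent swap can move the read-out strongly, and no measured step covers the new place. No change beyond the scatter is therefore expected in this assay, though with a wide margin in either direction. The expected change is a 1.2-fold lower number from compound 1 to compound 3 (0.08 log units; within the scatter). Compound 3 is estimated at 700 nM, with an expected range from 170 nM to 3500 nM.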

Compound 3, half-maximal inhibitory concentration: 35 nM
For compound 3 the middle estimate is 20-fold (1.30 log units) above the measured one, and the stated range ends above it.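

Going from phenyl to 3-methoxyphenyl shows that this ring, left without a substituent in the earlier compounds, is a sensitive place: in this assay, methoxy in place of hydrogen gives a 24-fold lower number from compound 1 to compound 3 (1.39 log units; beyond the scatter). The earlier step showed a large change at a different place and towards weaker inhibition, while this one shows that a single added methoxy can also move the read-out strongly towards stronger inhibition. Compound 2 is the only one of the three compounds resting on a limit of the assay, so this new step, unlike the earlier one, has an actual number at both ends: the limit of > 10000 nM in this assay, at which 1 of the 3 values shown sits.

The compounds shown leave open whether this change is particular to methoxy, or whether hydroxy, an amine or a longer chain such as ethoxy would do the same. They also leave open what methoxy would do elsewhere on this ring.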